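Swapping Fluoro for Methoxy: Expected Value for Compound 4

The compounds below may be only part of what the source reports. "The series", "measured", "known", "first", "only" and "open" are said of these compounds alone.

Measured compounds:
compound 1, `Cc1ccc(Cn2c(/C=C3\SC(=S)N(CC(=O)O)C3=O)nc3cc(F)ccc32)cc1`, 1170 nM
compound 2, `COc1ccc2c(c1)nc(/C=C1\SC(=S)N(CC(=O)O)C1=O)n2Cc1ccc(C)cc1`, 770 nM
compound 3, `O=C(O)CN1C(=O)/C(=C/c2nc3ccc(F)cc3n2Cc2ccccc2F)SC1=S`, 5230 nM

The three measured compounds were tested in a functional assay on HL-60 cells (Homo sapiens) for cytotoxicity, read by MTT assay, with a stated time of 48 h; a lower number here means a stronger inhibitor, a higher number a weaker inhibitor. Compound 1 and compound 2 differ in one place only: methoxy in place of fluoro on an aromatic carbon. The step that went with it is a 1.5-fold lower number from compound 1 to compound 2 (0.18 log units; within the scatter), so these two values cannot be told apart with confidence.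

Compound 3 carries the same fluoro group but a different core; the difference between the core of compound 3 and the core of compound 1 is not broken down here. Compound 3 gives the highest of the three numbers, and its distance from compound 1 and from compound 2 lies beyond the scatter.

Compound 4, `COc1ccc2nc(/C=C3\SC(=S)N(CC(=O)O)C3=O)n(Cc3ccccc3F)c2c1`, is not yet measured. It stands to compound 3 as compound 2 stands to compound 1: methoxy in place of fluoro on an aromatic carbon. The place of the change is described in the same words for both pairs, so this is the same change, made on the core of compound 3 rather than the core of compound 1.

Going by the values given here, with only one earlier example, the expectation rests on that single pair. Because compound 1 to compound 2 gave a 1.5-fold lower number from compound 1 to compound 2 (0.18 log units; within the scatter), the step from compound 3 to compound 4 is expected to be of similar size, a 1.5-fold lower number from compound 3 to compound 4 (0.17 log units; within the scatter). Compound 4 is therefore estimated at 3500 nM in this assay, with a likely range from 1500 nM to 9000 nM.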

Compound 4, half-maximal inhibitory concentration: 6440 nM
Estimate against measurement, compound 4: 1.8-fold (0.26 log units) below; the range from low to high includes it.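

In this assay, putting methoxy in place of fluoro on the second core gave a 1.2-fold higher number from compound 3 to compound 4 (0.09 log units; within the scatter), a step too small to separate the two compounds. Set beside the earlier example of the same change, the two steps cannot be told apart, so the change behaved alike on both cores as far as this measurement can tell: the same change on two cores in this assay, a 1.5-fold lower number (0.18 log units; within the scatter) from compound 1 to compound 2 and a 1.2-fold higher number (0.09 log units; within the scatter) from compound 3 to compound 4, 1.9-fold (0.27 log units) apart, within the scatter of two such steps. Going by these compounds alone, this shows only that the swap made no readable difference on either core; it does not show that the two groups are truly equivalent, and two pairs give no basis for predicting the result on a further core.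

The compounds shown leave open whether a different group on this aromatic carbon, such as an amine, a chloro group or a longer chain like ethoxy, would produce a step beyond the scatter. They also leave open whether the agreement between the two steps would hold on other cores or in cell types other than the one tested here.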